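This account rests on a few compounds, and the source may have more. Where it says the series, first, only, none or still open, it means among the compounds named here.

Three compounds share one core and differ only in a single group on an aromatic carbon. Compound 1 `O=S(=O)(Nc1ccc2oc(-c3ccccc3)nc2c1)c1ccccc1F` carries fluoro, compound 2 `O=S(=O)(Nc1ccc2oc(-c3ccccc3)nc2c1)c1ccccc1Cl` carries chloro and compound 3 `O=S(=O)(Nc1ccc2oc(-c3ccccc3)nc2c1)c1ccccc1O` carries hydroxy. All three were tested in an assay on isolated protein for inhibition of malate dehydrogenase, mitochondrial (Sus scrofa), with stated times of 45 min and 30 min; on this read-out higher numbers stand for weaker inhibition and lower numbers for stronger inhibition. There compound 1 gives > 63000 nM, which is a limit of the assay and not a number. Compound 2 likewise reaches only a limit, > 63000 nM. Compound 3 too stands at a limit, > 63000 nM. For the measured compounds named here, because all three sit at the limit of > 63000 nM in this assay, at which 3 of the 3 values shown sit, no step among them can be read: a step that the two limits leave unreadable from compound 1 to compound 2, a step that the two limits leave unreadable from compound 1 to compound 3 and a step that the two limits leave unreadable from compound 2 to compound 3 all stay hidden behind the limit. On the numbers shown, compound 3 therefore stands exactly where its two neighbours stand, at the limit, with nothing known beneath it.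

Compound 4 `O=S(=O)(Nc1ccc2oc(-c3ccccc3)nc2c1)c1ccccc1C(F)(F)F` has not yet been measured. It differs from compound 3 by trifluoromethyl in place of hydroxy on an aromatic carbon. Going by the values given here, none of the measured steps can say how large a change this brings; each of them is unreadable. Among the compounds with values here, the only guidance is that three different groups on the same carbon all left the result at the limit. The expected step is a step that the limit leaves unreadable from compound 3 to compound 4, no shift beyond the scatter. The estimate for compound 4 in this assay is 100000 nM, most likely again a limit, with a range from 30000 nM to 300000 nM.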

Compound 4, half-maximal inhibitory concentration: > 63000 nM
Compound 4: no number, only a limit (the forecaster's own chance of this, stated with the estimate: 85%); the middle value does not contradict the limit.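

In this assay compound 4 gives > 63000 nM, again a limit of the assay and not a number. For the compounds shown here, no step from compound 1, compound 2 or compound 3 to compound 4 can be read, because all four stand at the same limit: the limit of > 63000 nM in this assay, at which 4 of the 4 values shown sit. The compounds shown leave open how strongly any of them inhibits the enzyme, and whether swapping the group on this aromatic carbon changes that at all.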